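The source may hold more compounds than are shown below. What is called first, only, known or untested is meant among the compounds shown, and "the series" means these compounds.

Compound 1 `O=c1oc(CO)cc2ccccc12` and compound 2 `COc1ccc2cc(CO)oc(=O)c2c1` share one core; compound 3 `O=C1OC(CO)Cc2ccccc21` and compound 4 `COc1ccc2c(c1)C(=O)OC(CO)C2` share another, and the difference between the two cores is not broken down here. In a functional assay on 786-0 cells (Homo sapiens) for antiproliferative activity, read by sulforhodamine B assay, with a stated time of 48 h (a higher number here means a weaker inhibitor of growth, a lower number a stronger inhibitor of growth), compound 1 reaches only a limit, >= 250 ug/mL. Compound 2 gives 37.6 ug/mL in this assay. The change methoxy in place of hydrogen on an aromatic carbon thus brought an at least 6.6-fold lower number from compound 1 to compound 2 (0.82 log units; beyond the scatter). Compound 3 likewise reaches only a limit in this assay, >= 250 ug/mL, a point noted in the limit of >= 250 ug/mL in this assay, at which 2 of the 3 values shown sit. Compound 4 carries the same change, (methoxy in place of hydrogen on an aromatic carbon), on its own core. Because compound 1 to compound 2 moved by an at least 6.6-fold lower number from compound 1 to compound 2 (0.82 log units; beyond the scatter), the step from compound 3 to compound 4 in this assay is expected to be an at least 3.1-fold lower number from compound 3 to compound 4 (0.49 log units; beyond the scatter), though compound 3 offers only a limit to build on. Compound 4 is therefore estimated at 80 ug/mL, between 20 ug/mL and 250 ug/mL.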

Compound 4, concentration for 50% growth inhibition: >= 250 ug/mL
Compound 4 gave a limit, no number; the forecaster's own chance of this, stated with the estimate: 40%; middle value at least 3.1-fold (0.49 log units) away from the limit.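

In this assay, going by these compounds alone, compound 3 and compound 4 both give only a limit, so no step between them can be read: the limit of >= 250 ug/mL in this assay, at which 3 of the 4 values shown sit. From the compounds shown here alone, whether methoxy in place of hydrogen lowers the number on the core of compound 3, as it does on the core of compound 1, stays open.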